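The compounds below may be only part of what the source reports. "The series", "measured", "known", "first", "only" and "open" are said of these compounds alone.

Measured compounds:
compound 1, `CCN1CCN(c2cc(C)c3cc(NC(=O)c4ccc(Br)cc4)ccc3n2)CC1`: 5940 nM
compound 2, `Cc1cc(NCCN2CCCC2)nc2ccc(NC(=O)c3ccc(Cl)c(Cl)c3)cc12`: 1280 nM
compound 3, `Cc1cc(NCCN2CCCCC2)nc2ccc(NC(=O)c3ccc(Cl)c(Cl)c3)cc12`: 1190 nM

In a functional assay on MCF7 cells (Homo sapiens) for antiproliferative activity, read by MTT assay, with a stated time of 72 h (on this read-out lower numbers stand for stronger inhibition and higher numbers for weaker inhibition), compound 1 gives the highest number of the three. Compound 2 and compound 3 both give lower numbers, and both gaps to compound 1 lie beyond the scatter. Among the compounds with values here, the only one-place step among the measured compounds is a 1.1-fold lower number from compound 2 to compound 3 (0.03 log units; within the scatter); it concerns the saturated ring carried on the chain and says nothing about the bromine-bearing ring of the amide.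

Compound 4, `CCN1CCN(c2cc(C)c3cc(NC(=O)c4cccc(Br)c4)ccc3n2)CC1`, differs from compound 1 only in the amide aryl group: 3-bromophenyl in place of 4-bromophenyl on a carbonyl carbon. Within the data shown here, no measured pair in this set changes anything on that ring, so no step bears directly on this change. Compound 2 and compound 3 carry a different halogen pattern on the amide aryl group, but they also differ from compound 1 in the substituent on the core, so their values cannot be read as a step for the aryl change alone. With nothing to anchor the direction, the expected step from compound 1 is a 1.2-fold lower number from compound 1 to compound 4 (0.07 log units; within the scatter), none beyond the scatter, with the range widened to allow for the untested change. For compound 4 the estimate in this assay is 5000 nM, within 1800 nM to 14000 nM.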

Compound 4, half-maximal inhibitory concentration: 11600 nM
Compound 4: the middle estimate sits 2.3-fold (0.37 log units) below what was measured, and the stated range covers the measured number.
By their numbers in this assay, from the lowest: compounds 3 and 2 (each within the scatter of the next); then compounds 1 and 4 (each within the scatter of the next).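

The change of 3-bromophenyl for 4-bromophenyl on a carbonyl carbon gives the only step at the amide aryl ring among the compounds shown, and in this assay it reads a 2.0-fold higher number from compound 1 to compound 4 (0.29 log units; within the scatter). With the rest of the structure held fixed, the two bromine placements therefore cannot be told apart on this read-out, and neither placement can be ranked ahead of the other. No measured property or other supporting data bears on this result.

The compounds shown leave open whether the lower numbers of compound 2 and compound 3 belong to the dichlorophenyl amide or to the amine-bearing chain on the core, as each of the two differs from compound 1 in both places. They also leave open how this ring behaves with something other than bromine, such as a trifluoromethyl group or no substituent at all, on the otherwise unchanged structure of compound 1.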